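A few compounds are considered here, and "the series" means these few. Any claim that something is new, unique, unknown or untested is made for them only; others in the source may bear on it.

Compound 1 `[SeH]c1nc2ccccc2s1`: in a functional assay on MCF7 cells (Homo sapiens) for cytotoxicity, read by MTT assay, with a stated time of 72 h (on this read-out lower numbers stand for stronger inhibition of growth and higher numbers for weaker inhibition of growth), compound 1 gives > 50000 nM, which is a limit of the assay and not a number.
Compound 2 `[SeH]c1ccnc([SeH])n1`: in this assay compound 2 gives 6700 nM.
Compound 3 `O=C1c2ccccc2C(=O)N1CS`: in this assay compound 3 gives > 100000 nM, again a limit of the assay rather than a number.

Among the three values shown, compound 3 stands at the limit of > 100000 nM in this assay, at which 1 of the 3 values shown sits, while compound 1 sits at the limit of > 50000 nM in this assay, at which 1 of the 3 values shown sits; only compound 2 provides an actual number. No two of these compounds differ in a single place, so there is no measured step to guide the change. Compound 4 `N#C[Se]CN1C(=O)c2ccccc2C1=O` differs from compound 3 by a group of 3 heavy atoms (1 carbon, 1 nitrogen, 1 selenium; no ring) in place of one sulfur atom, on a saturated chain carbon bound to an amide-type nitrogen in a ring. For the measured compounds named here, with no measured step to lean on, the expectation rests on compound 2, whose selenium-bearing structure gives 6700 nM as the one number in hand. In this assay the expected step is an at least 5.0-fold lower number from compound 3 to compound 4 (0.69 log units; beyond the scatter), toward stronger inhibition of growth, though a limit is also quite possible. Compound 4 is estimated at 20000 nM, with a range from 5000 nM to 80000 nM.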

Compound 4, concentration for 50% growth inhibition: 15400 nM
Beside the measured number, compound 4's estimate is 1.3-fold (0.11 log units) above it; the range from low to high includes it.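

In this assay, putting the group of carbon, nitrogen and selenium in place of the sulfanyl group, on a saturated chain carbon bound to an amide-type nitrogen in a ring, gives an at least 6.4-fold lower number from compound 3 to compound 4 (0.81 log units; beyond the scatter), toward stronger inhibition of growth. For the compounds shown here, this is the first measured change at this place, and it gives the core of compound 3 an actual number, as compound 4 reads 15400 nM. Compound 3 stands at a limit of the assay and not at a number, so the size of the step is only a bound: the limit of > 100000 nM in this assay, at which 1 of the 4 values shown sits.

The step exchanges sulfur for selenium and brings in the nitrile at once, and the compounds shown do not separate the two, which a selenol or a thiocyanate at this place could do. Also open, going by these compounds, is how a longer chain in place of the saturated chain carbon would read in this assay.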